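Swapping the chain end amine for an anilino group

This account rests on a few compounds, and the source may have more. Where it says the series, first, only, none or still open, it means among the compounds named here.

Compound 2, `CN(C)CCCn1c(N)c(-c2nc3ccccc3[nH]2)c2nc(C#N)c(C#N)nc21`: 870 nM
Compound 1, `CCn1c(N)c(-c2nc3ccccc3[nH]2)c2nc(C#N)c(C#N)nc21`: > 50000 nM

In a functional assay on HL-60 cells (Homo sapiens) for antiproliferative activity, read by MTT assay, with a stated time of 48 h (on this read-out higher numbers stand for weaker inhibition and lower numbers for stronger inhibition), compound 2 gives 870 nM, the only number shown. Compound 1 reaches only a limit there, > 50000 nM (the limit of > 50000 nM in this assay, at which 1 of the 2 values shown sits). Among the compounds with values here, the step of an at least 57-fold lower number from compound 1 to compound 2 (1.75 log units; beyond the scatter) is the one measured change. Compound 3, `N#Cc1nc2c(-c3nc4ccccc4[nH]3)c(N)n(CCCNc3ccccc3)c2nc1C#N`, differs from compound 2 by anilino in place of dimethylamino on a saturated chain carbon, three bonds along the chain from an aromatic nitrogen. That removes the very group whose arrival gave the large gain, replacing it with a larger anilino end. The step from compound 2 to compound 3 is therefore expected to weaken inhibition, a 6.9-fold higher number from compound 2 to compound 3 (0.84 log units; beyond the scatter). Compound 3 is estimated at 6000 nM, between 1000 nM and 40000 nM.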

Compound 3, half-maximal inhibitory concentration: 6920 nM
Compound 3: middle estimate off by 1.2-fold (0.06 log units), on the low side, and the stated range covers the measured number.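

In this assay the gain does not belong to dimethylamino alone: an anilino end on the same chain still brings an at least 7.2-fold lower number from compound 1 to compound 3 (0.85 log units; beyond the scatter) and so keeps part of it. Of these two ends dimethylamino gives the stronger inhibition, as the swap to anilino leaves an 8.0-fold higher number from compound 2 to compound 3 (0.90 log units; beyond the scatter) on this position. Compound 1 gives only a limit: the limit of > 50000 nM in this assay, at which 1 of the 3 values shown sits.

Still open, on these data alone, is whether a ring amine such as piperidine or morpholine at the chain end would match dimethylamino. As far as these compounds go, a longer chain carrying the same dimethylamino group is equally open.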